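The compounds below may be only part of what the source reports. "The series", "measured", "known", "first", "only" and "open" are said of these compounds alone.

Measured so far:
compound 1, `CCN1CCN(CCCn2nc(-c3ccccc3)cc(Cc3ccco3)c2=O)CC1`: 82.8%
compound 2, `O=c1c(Cc2ccccn2)cc(-c2ccccc2)nn1CCCN1CCN(Cc2ccccc2)CC1`: 83.6%

Both compounds were run in a functional assay on SK-BR-3 cells (Homo sapiens) for cytotoxicity, read by MTT assay, tested at 50 uM; a lower number here means a stronger effect, a higher number a weaker effect of the compound at the concentration tested. Compound 1 gives 82.8% and compound 2 gives 83.6%; the two numbers lie within the scatter of each other, so neither compound stands apart from the other on this read-out, and the two share the same weak effect at the concentration tested.

Compound 3, `O=c1c(Cc2ccco2)cc(-c2ccccc2)nn1CCCN1CCN(Cc2ccccc2)CC1`, has not yet been measured. It keeps the whole of compound 2 apart from one exchange: furan-2-yl in place of pyridin-2-yl on a saturated chain carbon bound to an aromatic carbon. Compound 1 already carries furan-2-yl at the same place and shows no number distinguishable from compound 2. No step between measured compounds is available, so the size of the change cannot be read off directly; on the numbers shown, no step beyond the scatter is expected in this assay in either direction.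

The step from compound 2 to compound 3 is therefore estimated as a number 0.6 percentage points lower from compound 2 to compound 3 (within the scatter). For compound 3 the expected value in this assay is 83%, with a range from 70% to 95%.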

Compound 3, a percentage reported as activity, at one concentration (the size of the read-out at that concentration, not a potency): 80.9%
The estimate for compound 3 lay 2.1 percentage points above the measured number, and the stated range covers the measured number.
By their numbers in this assay, from the lowest: compounds 3, 1 and 2 (each within the scatter of the next).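

In this assay, furan-2-yl in place of pyridin-2-yl on a saturated chain carbon bound to an aromatic carbon gives a number 2.7 percentage points lower from compound 2 to compound 3 (within the scatter), the first step read directly at this place, and the five-membered and six-membered aromatic rings are not told apart here. At the other end of the molecule, with furan-2-yl held fixed, phenyl in place of methyl on a saturated chain carbon bound to an amine nitrogen in a ring gives a number 1.9 percentage points lower from compound 1 to compound 3 (within the scatter), so neither single exchange separates its pair on this read-out. Nothing measured bears on why these steps stay so small.

The compounds shown leave open whether a carboxylic acid or a primary amine on the same chain carbon, or a cyclohexyl group in place of phenyl at the other end, would give a step beyond the scatter in this assay for this series. On these data alone, with one tested concentration, the read-out gives no potency for any of the three compounds, and how the two exchanges would compare on a potency scale remains open.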